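From 2-chlorophenyl to 2-nitrophenyl in one cell assay

The compounds below may be only part of what the source reports. "The series", "measured", "known", "first", "only" and "open" are said of these compounds alone.

Compound 1 (`COc1cc(C(=O)c2cn(-c3cccc(F)c3)cc2-c2ccccc2[N+](=O)[O-])cc(OC)c1OC`): 190 nM
Compound 2 (`COc1cc(C(=O)c2cn(-c3ccc(F)cc3)cc2-c2ccccc2Cl)cc(OC)c1OC`): 83 nM

In a functional assay on MCF7 cells (Homo sapiens) for cytotoxicity, read by MTT assay, with a stated time of 96 h (on this read-out higher numbers stand for weaker inhibition and lower numbers for stronger inhibition), compound 2 gives 83 nM and holds the lower of the two numbers, with compound 1 higher by more than the scatter. Compound 3 (`COc1cc(C(=O)c2cn(-c3ccc(F)cc3)cc2-c2ccccc2[N+](=O)[O-])cc(OC)c1OC`) has nitro in place of chloro on an aromatic carbon. Compound 1 also carries the 2-nitrophenyl group and gives 190 nM in this assay and on that basis a modest rise in the number, meaning weaker inhibition, is expected. The expected 1.7-fold higher number from compound 2 to compound 3 (0.23 log units; within the scatter) may stay close to the scatter. Compound 3 is estimated at 140 nM (range 50 nM to 400 nM).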

Compound 3, half-maximal inhibitory concentration: 38 nM
The estimate for compound 3 lay 3.7-fold (0.57 log units) above the measured number; measured number outside the range, below it.
By their numbers in this assay, from the lowest: compound 3; then compound 2; then compound 1.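

With 4-fluorophenyl held fixed, 2-nitrophenyl in place of 2-chlorophenyl gives a 2.2-fold lower number from compound 2 to compound 3 (0.34 log units; beyond the scatter) in this assay and so strengthens inhibition at this place. With 2-nitrophenyl held fixed, 4-fluorophenyl in place of 3-fluorophenyl on an aromatic nitrogen gives a 5.0-fold lower number from compound 1 to compound 3 (0.70 log units; beyond the scatter) and so shows that the nitro group does not account for the higher number of compound 1. The data offer no explanation for either step. Going by these compounds, whether an amine or a nitrile on this aromatic carbon would lower the number further remains open. So does whether nitro in place of chloro gives a similar step with 3-fluorophenyl on the aromatic nitrogen.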